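This account rests on a few compounds, and the source may have more. Where it says the series, first, only, none or still open, it means among the compounds named here.

Compound 1 `COc1ccc(CN(C(=O)C2CC2)c2cc(OC)c(OC)c(OC)c2)cc1O` is the reference point of this small set. In a functional assay on MGC-803 cells (Homo sapiens) for inhibition, read by MTT assay, with a stated time of 48 h (on this read-out lower numbers stand for stronger inhibition and higher numbers for weaker inhibition), compound 1 gives 59 nM, the lowest of the three numbers recorded. Among the compounds with values here, compound 3 `COc1ccc(CN(C(=O)CBr)c2cc(OC)c(OC)c(OC)c2)cc1O` stands nearest, giving 140 nM in this assay; the step of a 2.4-fold higher number from compound 1 to compound 3 (0.38 log units; beyond the scatter) is the only single-point change measured so far. Compound 2 `COc1cc(NCc2cccc(O)c2)cc(OC)c1OC`, which lacks the acyl group on the nitrogen altogether, gives 57600 nM and lies far from both, so the acylated series is where the low numbers sit.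

Compound 4 `C/C=C/C(=O)N(Cc1ccc(OC)c(O)c1)c1cc(OC)c(OC)c(OC)c1` keeps the shared core of compound 1 and alters only the acyl group: prop-1-en-1-yl in place of cyclopropyl on a carbonyl carbon

Within the data shown here, the step that bears on this is the one from compound 1 to compound 3, where a different small acyl variation on the same carbonyl carbon gave a modest rise in number. Among the measured compounds shown here, a prop-1-en-1-yl group is of the same size as the cyclopropyl it replaces, and no measured step shows a large change from such exchanges on this carbonyl; compound 2 is not comparable, since the whole acyl group is absent there. A modest shift toward a higher number is therefore expected, of the order of a 1.7-fold higher number from compound 1 to compound 4 (0.23 log units; within the scatter), with a real chance that it falls within scatter. For compound 4 the estimate in this assay is 100 nM, with a range from 40 nM to 300 nM.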

Compound 4, half-maximal inhibitory concentration: 27 nM
Beside the measured number, compound 4's estimate is 3.7-fold (0.57 log units) above it; measured number below the stated range.
By their numbers in this assay, from the lowest: compound 4; then compound 1; then compound 3; then compound 2.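

In this assay, within the data shown here, prop-1-en-1-yl in place of cyclopropyl on the carbonyl carbon gives a 2.2-fold lower number from compound 1 to compound 4 (0.34 log units; beyond the scatter), so this is the one change at this position that takes the number below that of compound 1, whereas the bromomethyl exchange raised it. The three-membered ring is therefore not needed for a low number here, and an open chain with one double bond outside aromatic rings, carrying the same count of heavy atoms, does better than the ring. The same position also separates the two open-chain acyl groups, with a 5.2-fold lower number from compound 3 to compound 4 (0.71 log units; beyond the scatter), so the identity of the group on the carbonyl carbon still moves the number even among small substituents, and nothing available here explains why these groups fall in this order.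

Open, as far as these compounds go, is whether the lower number goes with the double bond or simply with the absence of a ring, a question that a saturated propyl group on the same carbonyl carbon would settle. Also open, from the compounds shown here alone, is whether the trend extends to a longer chain, or whether an amine at the end of the chain would keep the number this low.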